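Shrinking the Ring on a Thiocarbonyl Carbon

The compounds below may be only part of what the source reports. "The series", "measured", "known", "first", "only" and "open" are said of these compounds alone.

Of the compounds shown here, three have been tested in a functional assay on MCF7 cells (Homo sapiens) for inhibition, read by MTT assay, with stated times of 18 h and 4 h; a lower number here means a stronger inhibitor, a higher number a weaker inhibitor. Compound 1 `CCCCCCOP(=O)(O)OCCSC(=S)N1CCCC1` gives 100000 nM. Compound 2 `CCCCCCOP(=O)(O)OCCSC(=S)N1CCCCC1` gives 62000 nM, and compound 3 `CCCCCCCCCCCCCCCCOP(=O)(O)OCCSC(=S)N1CCCCC1` gives 29000 nM, the lowest of the three numbers. Compound 3 differs from compound 2 only by decyl in place of hydrogen on a saturated chain carbon, six bonds along the chain from an oxygen on an unsaturated carbon, a change that gave a 2.1-fold lower number from compound 2 to compound 3 (0.33 log units; beyond the scatter). Compound 1 differs from compound 2 by pyrrolidin-1-yl in place of piperidin-1-yl on a thiocarbonyl carbon, and that change gave a 1.6-fold higher number from compound 2 to compound 1 (0.21 log units; within the scatter).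

Compound 4 `CCCCCCCCCCCCCCCCOP(=O)(O)OCCSC(=S)N1CCCC1` has not yet been measured in this assay. It stands to compound 3 as compound 1 stands to compound 2: the difference is pyrrolidin-1-yl in place of piperidin-1-yl on a thiocarbonyl carbon, at the same place with the same neighbours, so this is the same change seen once before. The cores of compound 3 and compound 2 differ as described above.

The expected step is a 1.6-fold higher number from compound 3 to compound 4 (0.20 log units; within the scatter). Going by the values given here, this expectation rests on the one earlier example, because a 1.6-fold higher number from compound 2 to compound 1 (0.21 log units; within the scatter) arose from the identical change. Compound 4 is therefore expected to give about 46000 nM. For compound 4 the estimated range runs from 20000 nM to 110000 nM.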

Compound 4, half-maximal inhibitory concentration: 72000 nM
Compound 4: middle estimate off by 1.6-fold (0.19 log units), on the low side, and the stated range covers the measured number.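

On the core of compound 3, pyrrolidin-1-yl in place of piperidin-1-yl on the thiocarbonyl carbon gives a 2.5-fold higher number from compound 3 to compound 4 (0.39 log units; beyond the scatter) in this assay, and this step fits the earlier example of the same swap: the same change on two cores in this assay, a 1.6-fold higher number (0.21 log units; within the scatter) from compound 2 to compound 1 and a 2.5-fold higher number (0.39 log units; beyond the scatter) from compound 3 to compound 4, 1.5-fold (0.19 log units) apart, within the scatter of two such steps. The decyl change, read on the core of compound 1, gives a 1.4-fold lower number from compound 1 to compound 4 (0.14 log units; within the scatter), and it also fits its earlier counterpart: the same change on two cores in this assay, a 2.1-fold lower number (0.33 log units; beyond the scatter) from compound 2 to compound 3 and a 1.4-fold lower number (0.14 log units; within the scatter) from compound 1 to compound 4, 1.5-fold (0.19 log units) apart, within the scatter of two such steps. These two pairs show that each change carried over between these two cores in this one assay, but they do not show that either change would carry over to any other core, and they give no reason for the size of either step.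

As far as these compounds go, whether the same result would hold with a morpholin-4-yl group on the thiocarbonyl carbon remains open. The effect of an octyl chain in place of the chains shown also remains open, as does that of a dimethylamino group on either core.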